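Swapping the Styryl Arm for a Dimethylaminophenyl Group

The compounds below may be only part of what the source reports. "The series", "measured", "known", "first", "only" and "open" are said of these compounds alone.

Compound 1 `COC(=O)/C=C/c1cccc(N(Cc2ccc(/C=C/c3ccc(F)cc3)cc2)C(=O)C(C)C)c1` sits at the top of the three numbers in an assay on isolated protein with Bile acid receptor (Homo sapiens) as the target (a higher number here means that more compound is needed for the effect, a lower number that less compound is needed), giving 120 nM, though all three lie within the scatter of one another. Compound 2 `COC(=O)/C=C/c1cccc(N(Cc2ccc(-c3ccc(F)c(F)c3)cc2)C(=O)C2CCCCC2)c1` gives 72 nM and compound 3 `COC(=O)/C=C/c1cccc(N(Cc2ccc(-c3cccc(C)c3)cc2)C(=O)C2CCCCC2)c1` gives 109 nM. Going by the values given here, the only single-point step measured, a 1.5-fold higher number from compound 2 to compound 3 (0.18 log units; within the scatter), exchanges the outer aryl on a different amide and stays within the scatter. Compound 4 `COC(=O)/C=C/c1cccc(N(Cc2ccc(-c3ccc(N(C)C)cc3)cc2)C(=O)C(C)C)c1` keeps the core of compound 1 and differs by 4-(dimethylamino)phenyl in place of 2-(4-fluorophenyl)ethenyl on an aromatic carbon. Among the compounds with values here, no measured step exchanges this particular group, so the step of no change at the digits printed from compound 1 to compound 4 (within the scatter) is expected to stay within the scatter. Compound 4 is therefore estimated at 120 nM, with a range from 50 nM to 300 nM.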

Compound 4, half-maximal effective concentration: 57 nM
Compound 4: middle estimate off by 2.1-fold (0.32 log units), on the high side; measured number inside the range.
By their numbers in this assay, from the lowest: compounds 4, 2, 3 and 1 (each within the scatter of the next, the first and the last beyond it).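

At this position, on an aromatic carbon para to a large group, 4-(dimethylamino)phenyl in place of 2-(4-fluorophenyl)ethenyl gives a 2.1-fold lower number from compound 1 to compound 4 (0.32 log units; beyond the scatter) in this assay, the only step shown that lies beyond the scatter. The two groups match in heavy-atom count, but the entering group has a nitrogen and a hydrogen-bond acceptor and lacks the fluorine and the double bond. Nothing available indicates which of these differences matters. As far as these compounds go, it remains open whether the dimethylamino group or the loss of the ethenyl link carries the step, which a 4-fluorophenyl group on the core of compound 1 would help separate. From the compounds shown here alone, whether the step holds with the cyclohexyl amide of compound 2 and compound 3 is also open.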